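This account rests on a few compounds, and the source may have more. Where it says the series, first, only, none or still open, it means among the compounds named here.

Measured in a functional assay on DU-145 cells (Homo sapiens) for antiproliferative activity, read by MTT assay, with a stated time of 48 h; a lower number here means a stronger inhibitor, a higher number a weaker inhibitor:
Compound 1 `COc1ccc(-c2nnc(-c3cn4ccccc4n3)o2)cc1`: 12900 nM
Compound 2 `COc1ccc(-c2nnc(-c3cn4cccc(C)c4n3)o2)cc1`: 10800 nM
Compound 3 `Cc1cccn2cc(-c3nnc(-c4ccc(N(C)C)cc4)o3)nc12`: 10800 nM

Compound 2 reads the same as compound 3 at the digits given, and it lies within the scatter of compound 1, so the three form a single level in this assay. Compound 4 `COc1ccc(-c2nnc(-c3cn4cccc(C)c4n3)o2)cc1OC` is compound 2 with one change: methoxy in place of hydrogen on an aromatic carbon.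

Going by the values given here, two measured steps bear on this change, though neither adds this group. Methyl in place of hydrogen on an aromatic carbon gave a 1.2-fold lower number from compound 1 to compound 2 (0.08 log units; within the scatter), and dimethylamino in place of methoxy on an aromatic carbon gave no change at the digits printed from compound 2 to compound 3 (within the scatter). Both are small, so the series has so far shown no step beyond the scatter. Among the compounds with values here, no measured compound carries the added methoxy, which leaves the range wide.

The expected change is slight, with an estimated 1.4-fold lower number from compound 2 to compound 4 (0.13 log units; within the scatter), and no shift beyond the scatter is expected. For compound 4 the estimated value is 8000 nM, with an expected range of 3000 nM to 20000 nM.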

Compound 4, half-maximal inhibitory concentration: 11800 nM
Compound 4: the middle estimate sits 1.5-fold (0.17 log units) below what was measured, within the range that was stated.
By their numbers in this assay, from the lowest: compounds 2, 3, 4 and 1 (each within the scatter of the next).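

Methoxy in place of hydrogen on this aromatic carbon, ortho to a methoxy group and meta to a large group, is the first change shown at this position, and in this assay it gives a 1.1-fold higher number from compound 2 to compound 4 (0.04 log units; within the scatter) and so stays within the scatter. The position therefore accepts this added group without a measurable shift in this assay, and no step among the compounds shown lies beyond the scatter. Nothing available explains this flat result.

The compounds shown leave open whether a different group on the same carbon, such as a hydroxyl, an amine or a carboxylic acid, would move the number beyond the scatter. They also leave open whether a longer chain in place of the added methoxy would do so.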